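This account rests on a few compounds, and the source may have more. Where it says the series, first, only, none or still open, it means among the compounds named here.

Of the compounds shown here, three built on a shared core have been tested in a functional assay on the whole organism (Tail, strain ICR) with Mus musculus as the target, in the tail flick test, with a stated time of 120 min, at a dose of 25 umol/kg by the oral route; a higher number here means a stronger effect of the compound at the dose given, a lower number a weaker effect. Compound 1, `NC(=O)CC[C@H](NC(=O)CN(c1ncnc2c1ncn2C1CCCCO1)C1CC1)C(=O)OCc1ccccc1`, gives 22.3% in this assay. Compound 2, `O=C(CN(c1ncnc2c1ncn2C1CCCCO1)C1CC1)N[C@@H](CCC(=O)OCc1ccccc1)C(=O)OCc1ccccc1`, gives 20.7% in this assay. Compound 3, `NC(=O)C[C@H](NC(=O)CN(c1ncnc2c1ncn2C1CCCCO1)C1CC1)C(=O)OCc1ccccc1`, gives 29.2% in this assay. Compound 4, `O=C(CN(c1ncnc2c1ncn2C1CCCCO1)C1CC1)N[C@@H](CC(=O)OCc1ccccc1)C(=O)OCc1ccccc1`, has not yet been tested.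

Compound 1 and compound 2 differ in one place, (benzyloxy in place of amino on a carbonyl carbon), and this change gave a step of a number 1.6 percentage points lower from compound 1 to compound 2 (within the scatter). Compound 3 and compound 4 differ by benzyloxy in place of amino on a carbonyl carbon, and the place where the change sits is described in the same words for both pairs, so the change is the same one made at a second starting point. The two starting points differ from each other by carbamoyl in place of carbamoylmethyl on a saturated chain carbon, two bonds along the chain from an amide-type nitrogen and a carbonyl carbon; that change between compound 1 and compound 3 gave a step of a number 6.9 percentage points higher from compound 1 to compound 3 (within the scatter).

For the measured compounds named here, because the first occurrence gave a step of a number 1.6 percentage points lower from compound 1 to compound 2 (within the scatter), the step from compound 3 to compound 4 is expected to be similar, about a number 1.7 percentage points lower from compound 3 to compound 4 (within the scatter). The estimate for compound 4 in this assay is 27.5%, with a likely range from 17% to 37%, and that estimate rests on a single earlier occurrence, so its range is kept wide.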

Compound 4, a percentage reported as activity, at one dose (the size of the read-out at that dose, not a potency): 7.82%
For compound 4 the middle estimate is 19.7 percentage points above the measured one, and the stated range ends above it.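

The change of amino to benzyloxy on a carbonyl carbon did not carry over from one core to the other in this assay, so the result at one core was a poor guide to the result at the other: the same change on two cores in this assay, a number 1.6 percentage points lower (within the scatter) from compound 1 to compound 2 and a number 21.4 percentage points lower (beyond the scatter) from compound 3 to compound 4, 19.8 percentage points apart, beyond the scatter of two such steps.

At the second core the fall is a number 21.4 percentage points lower from compound 3 to compound 4 (beyond the scatter), and compound 4 also stands clearly under the two other compounds, with a number 12.9 percentage points lower from compound 2 to compound 4 (beyond the scatter) and a number 14.5 percentage points lower from compound 1 to compound 4 (beyond the scatter), which makes it the lowest of the four. This shows that the effect of the change depended on the core in these two pairs, but with one pair per core and a read-out at a single dose, it gives neither a reason for the difference nor a rule for other cores.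

Still open, on these data alone, is how a carboxylic acid or a methyl ester on the same carbonyl carbon would behave on each core. Also open, as far as these compounds go, is whether a longer chain would follow compound 1 and compound 2, where the change made little difference, or compound 3 and compound 4, where it made a large one.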